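Methylating the amide nitrogen of compound 1

The source may report more compounds than this note shows. Statements on the series, on what has been measured and on what is new or still open speak of the compounds shown alone.

Going by the values given here, compound 1 `COc1ccc2nc(C)cc(OCC(=O)Nc3cc(C)cc(C)c3)c2c1` is the only compound of three to return a number in a toxicity assay on HepG2 cells (Homo sapiens) for inhibition, read by CellTiter-Glo, with a stated time of 48 h; a lower number here means a stronger inhibitor, a higher number a weaker inhibitor: there compound 1 gives 20000 nM. Compound 2 `CCOc1ccc2nc(C)cc(OCC(=O)Nc3cc(C)cc(C)c3)c2c1` carries a methyl in place of hydrogen on a saturated chain carbon bound to an oxygen on an aromatic ring. In this assay compound 2 gives > 100000 nM, which is a limit of the assay. Compound 3 `COc1ccc2nc(C)cc(OCC(=O)Nc3cccnc3)c2c1` bears pyridin-3-yl in place of 3,5-dimethylphenyl on an amide-type nitrogen. In this assay compound 3 gives > 100000 nM, again a limit. The two measured steps, an at least 5.0-fold higher number from compound 1 to compound 2 (0.69 log units; beyond the scatter) and an at least 5.0-fold higher number from compound 1 to compound 3 (0.69 log units; beyond the scatter), both lie beyond the scatter and both run toward (the limit of > 100000 nM in this assay, at which 2 of the 3 values shown sit). Compound 4 `COc1ccc2nc(C)cc(OCC(=O)N(C)c3cc(C)cc(C)c3)c2c1` differs from compound 1 by methyl in place of hydrogen on an amide-type nitrogen. Neither measured step touches this hydrogen, so they bear on it only as two small changes to compound 1 that each gave a higher number. On that basis compound 4 is expected to give a higher number, estimated at 60000 nM with a range from 15000 nM to 200000 nM, which would mean a step of a 3.0-fold higher number from compound 1 to compound 4 (0.48 log units; beyond the scatter).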

Compound 4, half-maximal inhibitory concentration: 50100 nM
Compound 4: the middle estimate sits 1.2-fold (0.08 log units) above what was measured; the range from low to high includes it.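

Replacing the amide hydrogen with methyl moves the number the same way as the two earlier changes to compound 1, and here the size can be read: in this assay the step is a 2.5-fold higher number from compound 1 to compound 4 (0.40 log units; beyond the scatter). Going by these compounds alone, this is the first reading at this amide-type nitrogen, and it shows that a single added carbon there, with no ring, is enough to carry the number beyond the scatter. Compound 2 and compound 3, by contrast, each rest on a limit of the assay and so give no exact size: the limit of > 100000 nM in this assay, at which 2 of the 4 values shown sit. On these data alone, whether a larger group on this nitrogen, such as ethyl or a longer chain ending in an amine, would raise the number further stays open. As far as these compounds go, the methyl step also cannot be ranked against the other two changes, whose true sizes remain unknown.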